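Aryl thiazolidinone series: cytotoxicity, fluoro for nitro

This account rests on a few compounds, and the source may have more. Where it says the series, first, only, none or still open, it means among the compounds named here.

Measured compounds and their values:
compound 1 `O=C1CSC(c2cccc(Cl)c2)N1CCN1CCCCC1` – 100%
compound 2 `O=C1CSC(c2cccc(O)c2)N1CCN1CCCCC1` – 100%
compound 3 `O=C1CSC(c2ccc([N+](=O)[O-])cc2)N1CCN1CCCCC1` – 100%

In an ADME assay on Vero cells (Chlorocebus sabaeus) for cytotoxicity, read by neutral red uptake, tested at 12.3 ug/mL (a lower number here means a stronger effect, a higher number a weaker effect of the compound at the concentration tested), compound 1 gives 100% and compound 2 gives 100%. Among the compounds with values here, the only single-point step among the measured compounds, hydroxy in place of chloro on an aromatic carbon, is no change at the digits printed from compound 1 to compound 2 (within the scatter). Compound 3 stands level with both: in this assay compound 3 gives 100%, within the scatter of compound 1 and of compound 2 alike. On the numbers available the aromatic substituent has not moved the read-out at all.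

Compound 4 `O=C1CSC(c2ccc(F)cc2)N1CCN1CCCCC1` is not yet measured in this assay. It differs from compound 3 by fluoro in place of nitro on an aromatic carbon. Within the data shown here, no measured step covers the exchange of a nitro for a fluoro, so the step from compound 1 to compound 2 is the only guide, and it was flat. Three substituents of different kind have given the same flat read-out, so no change beyond the scatter is expected for compound 4, that is no change at the digits printed from compound 3 to compound 4 (within the scatter) as the expected step. In this assay compound 4 is therefore expected to give 100%, with a range from 90% to 105%.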

Compound 4, a percentage reported as activity, at one concentration (the size of the read-out at that concentration, not a potency): 100%
Compound 4: the middle estimate sits on the measured number at the digits printed, within the range that was stated.
By their numbers in this assay, from the lowest: compounds 1, 2, 3 and 4 (each within the scatter of the next).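

In this assay, within the data shown here, the first direct exchange at the position para to a large group, fluoro in place of nitro on an aromatic carbon, gives no change at the digits printed from compound 3 to compound 4 (within the scatter), so this position tolerates the replacement of the nitro group by the fluoro group without a readable shift at the tested concentration. The two exchanges of the whole aryl group read the same way: 4-fluorophenyl in place of 3-hydroxyphenyl gives no change at the digits printed from compound 2 to compound 4 (within the scatter), and 4-fluorophenyl in place of 3-chlorophenyl gives no change at the digits printed from compound 1 to compound 4 (within the scatter), so the flat picture now holds for all four aryl groups shown, with no compound against it. No supporting measurement bears on this result, and the flat read-out remains without an explanation.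

Since every compound shown sits at the same level, the series does not yet show which aromatic substituent, if any, would lower the read-out, and a carboxylic acid or a primary amine on the aromatic ring would test that. The shared core and its side chain stay constant throughout, so the effect of a longer chain in that side chain also remains open, as does the behaviour of these compounds at any other concentration.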